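From 3-fluorophenyl to 5-fluoropyridin-3-yl on compound 1

This account rests on a few compounds, and the source may have more. Where it says the series, first, only, none or still open, it means among the compounds named here.

In a functional assay on MDA-MB-231 cells (Homo sapiens) for cytotoxicity, read by MTT assay, with a stated time of 72 h (a lower number here means a stronger inhibitor, a higher number a weaker inhibitor), compound 1 `Nc1ccccc1NC(=O)c1ccc(NC(=S)NCc2cccc(F)c2)cc1` gives 74000 nM and compound 2 `Nc1ccccc1NC(=O)c1ccc(CNC(=O)c2cc3cnccc3[nH]2)cc1` gives 48000 nM with the two numbers within the scatter of each other. Compound 3 `Nc1ccccc1NC(=O)c1ccc(Cn2cc(-c3ccc(NC(=O)NCc4cccnc4)cc3)nn2)cc1` reports > 100000 nM as a limit and not a number. Compound 4 `Nc1ccccc1NC(=O)c1ccc(NC(=S)NCc2cncc(F)c2)cc1` carries 5-fluoropyridin-3-yl in place of 3-fluorophenyl on a saturated chain carbon bound to an amide-type nitrogen, with 5-fluoropyridin-3-yl in place of 3-fluorophenyl on a saturated chain carbon bound to an amide-type nitrogen as the whole difference from compound 1. Going by the values given here, no measured pair shows this change, so in this assay no step beyond the scatter is expected, with any drift more likely toward a weaker number. The expected step of a 1.1-fold higher number from compound 1 to compound 4 (0.03 log units; within the scatter) stays within the scatter. For compound 4 the estimate is 80000 nM with an expected range of 40000 nM to 160000 nM and a real chance of a limit in place of a number.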

Compound 4, half-maximal inhibitory concentration: 85000 nM
Compound 4: the middle estimate sits 1.1-fold (0.03 log units) below what was measured, and the stated range covers the measured number.
By their numbers in this assay, from the lowest: compounds 2, 1 and 4 (each within the scatter of the next). At a limit, above all of these: compound 3.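

In this assay, going by these compounds alone, the exchange of 3-fluorophenyl for 5-fluoropyridin-3-yl on a saturated chain carbon bound to an amide-type nitrogen gives the first measured step at this position (a 1.1-fold higher number from compound 1 to compound 4 (0.06 log units; within the scatter)). Adding a ring nitrogen, and with it one hydrogen-bond acceptor, therefore produces no readable change here. Compound 3 remains a limit and not a number: the limit of > 100000 nM in this assay, at which 1 of the 4 values shown sits. Going by these compounds, whether an amine or a carboxylic acid in place of the fluorine, or a longer chain in place of the saturated chain carbon, would move the number beyond the scatter stays open.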